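This account rests on a few compounds, and the source may have more. Where it says the series, first, only, none or still open, it means among the compounds named here.

Three compounds have been measured in a functional assay on MG-63 cells (Homo sapiens) for inhibition, read by CCK-8 assay, with a stated time of 72 h, tested at 1 uM; on this read-out higher numbers stand for more inhibition at the one concentration tested (going by the name of the read-out) and lower numbers for less inhibition:

Compound 1 `COc1ccc(F)cc1N1C(=O)CSC1c1cccc(C(=O)NCCCCc2ccccc2)c1` gives 86%.
Compound 2 `COc1cc(F)ccc1N1C(=O)CSC1c1cccc(C(=O)NCCCCc2ccccc2)c1` gives 92%.
Compound 3 `COc1cccc(OC)c1N1C(=O)CSC1c1cccc(C(=O)NCCCCc2ccccc2)c1` gives 80%.

Compound 3 holds the lowest of the three numbers; the two gaps are a number 6 percentage points lower from compound 1 to compound 3 (within the scatter) and a number 12 percentage points lower from compound 2 to compound 3 (beyond the scatter). Compound 4 `CC(F)(F)c1cccc(N2C(=O)CSC2c2cccc(C(=O)NCCCCc3ccccc3)c2)c1` differs from compound 3 by a group of 10 heavy atoms (8 carbon, 2 fluorine; one six-membered aromatic ring of carbon only) in place of a group of 10 heavy atoms (8 carbon, 2 oxygen; one six-membered aromatic ring of carbon only), on an amide-type nitrogen in a ring. All three measured steps exchange one aryl group on that same amide-type nitrogen for another: a number 6 percentage points higher from compound 1 to compound 2 (within the scatter), a number 6 percentage points lower from compound 1 to compound 3 (within the scatter) and a number 12 percentage points lower from compound 2 to compound 3 (beyond the scatter), none large. The expectation for compound 4 is therefore a step of a number 4 percentage points higher from compound 3 to compound 4 (within the scatter), not beyond the scatter, in this assay. Compound 4 is estimated at 84%, with a range from 70% to 95%.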

Compound 4, a percentage reported as inhibition, at one concentration (the size of the read-out at that concentration, not a potency): 92%
The estimate for compound 4 lay 8 percentage points below the measured number; measured number inside the range.
By their numbers in this assay, from the lowest: compounds 3, 1, 2 and 4 (each within the scatter of the next, the first and the last beyond it).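

In this assay, the aryl group on the amide-type nitrogen proves not to need a methoxy group: the entering group has no oxygen and no hydrogen-bond acceptors, yet replacing 2,6-dimethoxyphenyl with it gives a number 12 percentage points higher from compound 3 to compound 4 (beyond the scatter). It also stands level with the two fluorinated methoxy-bearing aryl groups, at no change at the digits printed from compound 2 to compound 4 (within the scatter) and a number 6 percentage points higher from compound 1 to compound 4 (within the scatter). Nothing available gives a reason for these steps.

As far as these compounds go, whether this position would keep its inhibition with a carboxylic acid or an amine on the aryl ring, or with a saturated cyclohexyl ring in place of the aryl ring, stays open. A single concentration also leaves open how far the compounds that read level differ in potency.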